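Adding isopropyl to compound 1: what to expect

This account rests on a few compounds, and the source may have more. Where it says the series, first, only, none or still open, it means among the compounds named here.

Compound 1 `O=C(O)COc1ccc(NCc2cccc(-c3ccccc3)c2)cc1F`: 2.25
Compound 2 `O=C(O)COc1ccc(NCc2ccc(Cl)c(-c3ccccc3)c2)cc1F`: 2.74

For the measured compounds named here, in a physicochemical assay for lipophilicity, read by HPLC, in phosphate buffer, measured as octanol-water partition, at pH 7.4, tested at 100 uM (a higher number here means a more lipophilic compound, a lower number a more polar compound), compound 1 gives 2.25, the lower of the two numbers measured so far, and the gap up to compound 2 lies beyond the scatter.

The next compound to be measured is compound 3 `CC(C)c1ccccc1-c1cccc(CNc2ccc(OCC(=O)O)c(F)c2)c1`. Its difference from compound 1 is isopropyl in place of hydrogen on an aromatic carbon, ortho to a large group. Cut one bond further out, the same change reads phenyl to 2-isopropylphenyl.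

Going by the values given here, only one measured step bears on this, and it is a modest one: a number 0.49 log units higher from compound 1 to compound 2 (beyond the scatter), with chloro in place of hydrogen on an aromatic carbon. It is a similar kind of swap, but at a different place and with a different group. Among the compounds with values here, no measured step involves isopropyl, so this single step is a thin guide. Going by it, a rise somewhat larger than that one seems likely, as isopropyl is the bigger group.

The expected change is a number 0.80 log units higher from compound 1 to compound 3 (beyond the scatter), upward and beyond the scatter. For compound 3 the estimate is 3.05, with an expected range of 2.65 to 3.5.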

Compound 3, distribution coefficient: 3.45
Compound 3: middle estimate off by 0.40 log units, on the low side; the range from low to high includes it.
By their numbers in this assay, from the lowest: compound 1; then compound 2; then compound 3.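

In this assay, isopropyl in place of hydrogen on an aromatic carbon, ortho to a large group, gives a number 1.20 log units higher from compound 1 to compound 3 (beyond the scatter). This is a large step, whereas the only earlier one, chloro in place of hydrogen at a different place on the molecule, was modest: a number 0.49 log units higher from compound 1 to compound 2 (beyond the scatter). For the compounds shown here, it is also the first measurement at this position, and it shows that phenyl to 2-isopropylphenyl, a change that adds 3 carbon atoms with no ring, no hydrogen-bond donors or acceptors and no net charge, can move the number a long way from the core of compound 1, though nothing at hand explains the size of this step.

With isopropyl as the only group shown at this position, it remains open whether a methyl group, a methoxy group or an amine in the same place would raise the number, lower it or leave it within the scatter. On these data alone, it is also open whether isopropyl would give a step of the same size on compound 2, which already carries chloro.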